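A few compounds are considered here, and "the series" means these few. Any claim that something is new, unique, unknown or untested is made for them only; others in the source may bear on it.

Compound 3 `Cc1ccc(S(=O)(=O)Nc2ccc3c(c2)C(=O)N(Cc2ccccc2)C3=O)cc1` is one of three measured members of the series. In an assay on isolated protein for inhibition of lysosomal alpha-glucosidase (Rattus norvegicus), read by colorimetric assay (on this read-out lower numbers stand for stronger inhibition and higher numbers for weaker inhibition), compound 3 gives only a limit, > 200000 nM. Compound 2 `Cc1ccc(S(=O)(=O)Nc2ccc3c(c2)C(=O)N(CCCCBr)C3=O)cc1` likewise reaches only a limit, > 200000 nM. Compound 1 `Cc1ccc(S(=O)(=O)Nc2ccc3c(c2)C(=O)N(CCNc2ccc(O)c(O)c2)C3=O)cc1` gives a number, 28800 nM. The steps of an at least 6.9-fold higher number from compound 1 to compound 2 (0.84 log units; beyond the scatter) and an at least 6.9-fold higher number from compound 1 to compound 3 (0.84 log units; beyond the scatter) both end at that limit, (the limit of > 200000 nM in this assay, at which 2 of the 3 values shown sit), and a step that the two limits leave unreadable from compound 2 to compound 3 cannot be read. Compound 4 `Cc1ccc(S(=O)(=O)Nc2ccc3c(c2)C(=O)N(Cc2ccccc2F)C3=O)cc1` differs from compound 3 by fluoro in place of hydrogen on an aromatic carbon. Going by the values given here, no measured step touches the benzyl ring itself, so none gives a size for this change; with compound 3 already at the limit, the expected step of a number no higher from compound 3 to compound 4 (the limit leaves the size open) is small. Compound 4 is estimated at 200000 nM, in a range from 60000 nM to 700000 nM, most probably again a limit in this assay.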

Compound 4, half-maximal inhibitory concentration: 195000 nM
Beside the measured number, compound 4's estimate is 1.0-fold (0.01 log units) above it; the measured number falls inside the stated range.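

In this assay, going by these compounds alone, the 2-fluorobenzyl group brings the first full number on the benzyl side, which gives the comparison with the (3,4-dihydroxyphenyl)amino chain a firm size: a 6.8-fold higher number from compound 1 to compound 4 (0.83 log units; beyond the scatter). Fluoro on this aromatic carbon, ortho to a large group, shows no readable gain over hydrogen or over the 3-bromopropyl group, since only floors are available: an at least 1.0-fold lower number from compound 3 to compound 4 (0.01 log units; that floor lies within the scatter) and an at least 1.0-fold lower number from compound 2 to compound 4 (0.01 log units; that floor lies within the scatter). Compound 3 remains a limit: the limit of > 200000 nM in this assay, at which 2 of the 4 values shown sit.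

Going by these compounds, whether chloro, methoxy or an amine on the benzyl ring would move the number stays open. Which part of the (3,4-dihydroxyphenyl)amino group carries the stronger inhibition also stays open.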